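The compounds below may be only part of what the source reports. "The series", "measured", "known", "first", "only" and "open" are said of these compounds alone.

Among the compounds with values here, in a functional assay on MT2 cells (Homo sapiens) for cytotoxicity, read by MTT assay (on this read-out higher numbers stand for lower toxicity in this test and lower numbers for higher toxicity in this test), compound 1 `Clc1ccc(Nc2nccs2)cc1OCc1ccoc1` gives 26000 nM, the highest of the three numbers so far. Compound 2 `N#Cc1ccc(Nc2nccs2)cc1OCc1ccsc1` gives 1100 nM, and compound 3 `N#Cc1ccc(Nc2nccs2)cc1OCC1=CCCC1` gives 1700 nM. Compound 4 `Clc1ccc(Nc2nccs2)cc1OCC1CCCCC1` differs from compound 1 in one place, with cyclohexyl in place of furan-3-yl on a saturated chain carbon bound to an oxygen on an aromatic ring. Within the data shown here, one measured step bears on this, since it also replaces an aromatic ring with a non-aromatic one at that place: cyclopent-1-en-1-yl in place of thiophen-3-yl, a 1.5-fold higher number from compound 2 to compound 3 (0.19 log units; within the scatter). The core of those two compounds differs from that of compound 1, so this is only a guide. No change beyond the scatter is therefore expected, and the estimated step is a 1.2-fold lower number from compound 1 to compound 4 (0.07 log units; within the scatter). For compound 4 the estimated value is 22000 nM, with an expected range from 8000 nM to 60000 nM.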

Compound 4, half-maximal cytotoxic concentration: 15000 nM
Compound 4: the middle estimate sits 1.5-fold (0.17 log units) above what was measured; the range from low to high includes it.
By their numbers in this assay, from the lowest: compounds 2 and 3 (each within the scatter of the next); then compounds 4 and 1 (each within the scatter of the next).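

In this assay, cyclohexyl in place of furan-3-yl gives a 1.7-fold lower number from compound 1 to compound 4 (0.24 log units; within the scatter), so this change of ring at this place does not separate the two compounds. The step also removes the hydrogen-bond acceptor counted for furan-3-yl, and the number still stays within the scatter, now on the core of compound 1 rather than the core of compounds 2 and 3. No measurement shown gives a reason for this result. Still open, as far as these compounds go, is whether an amine, a carboxylic acid or a longer chain at this place would move the number beyond the scatter.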